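A few compounds are considered here, and "the series" means these few. Any claim that something is new, unique, unknown or untested is made for them only; others in the source may bear on it.

Measured so far in a functional assay on OVCAR-4 cells (Homo sapiens) for antiproliferative activity, read by WST assay, with a stated time of 3 days; a higher number here means a weaker inhibitor, a lower number a stronger inhibitor:
- Compound 1 `O=c1cc(I)n([C@@H]2O[C@H](CO)[C@@H](O)[C@H]2O)c(=O)[nH]1`: > 50000 nM
- Compound 2 `Nc1cc(=O)[nH]c(=O)n1[C@@H]1O[C@H](CO)[C@@H](O)[C@H]1O`: > 50000 nM

Neither entry is a true number. Compound 1 gives > 50000 nM, which is a limit of the assay. Compound 2 gives > 50000 nM, which is the same limit. So compound 2 has no measured potency of its own, and the two compounds share one ceiling: the limit of > 50000 nM in this assay, at which 2 of the 2 values shown sit.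

The next compound, compound 3 `CN(C)c1cc(=O)[nH]c(=O)n1[C@@H]1O[C@H](CO)[C@@H](O)[C@H]1O`, has dimethylamino in place of amino on an aromatic carbon, next to the ring nitrogen: dimethylamino in place of amino on an aromatic carbon.

Within the data shown here, only one measured step can guide the expectation, a step that the two limits leave unreadable from compound 1 to compound 2, where amino replaces iodo. It has no readable size, so it offers no magnitude or direction to carry over. The likeliest outcome in this assay is therefore another reading at the limit, although a measurable value just inside the assay's range remains possible.

For compound 3 the estimated value is 40000 nM, with an expected range of 10000 nM to 50000 nM. The expected change is an at least 1.2-fold lower number from compound 2 to compound 3 (0.09 log units; that floor lies within the scatter).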

Compound 3, half-maximal inhibitory concentration: > 50000 nM
Compound 3: a limit, no number; the forecaster's own chance of this, stated with the estimate: 65%; at least 1.2-fold (0.09 log units) between middle value and limit.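

In this assay compound 3 gives > 50000 nM, which is a limit and not a number. No step from compound 1 or compound 2 to compound 3 can therefore be read, and all three compounds share one ceiling: the limit of > 50000 nM in this assay, at which 3 of the 3 values shown sit.

The compounds shown leave open whether iodo, amino and dimethylamino differ at all in potency, since none has a measured number.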